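Amino for Methoxy on the Benzylamide of Compound 3

A few compounds are considered here, and "the series" means these few. Any claim that something is new, unique, unknown or untested is made for them only; others in the source may bear on it.

Of the compounds shown here, three sharing one core have been tested in a toxicity assay on HepG2 2.2.15 cells (Homo sapiens) for cytotoxicity, read by CCK-8 assay, with a stated time of 8 days; a lower number here means that less compound is tolerated, a higher number that more compound is tolerated. Compound 1 `CC(C)Cc1nn(-c2nccs2)cc1C(=O)Nc1ccc(F)cc1` gives 83700 nM. Compound 2 `CC(C)Cc1nn(-c2nccs2)cc1C(=O)NCc1ccc(O)cc1` reaches only the limit of this assay, at > 100000 nM. Compound 3 `COc1ccc(CNC(=O)c2cn(-c3nccs3)nc2CC(C)C)cc1` likewise reaches only the limit, at > 100000 nM. Compound 3 therefore stands at the top of the numbers shown, a position it shares with compound 2, as the limit of > 100000 nM in this assay, at which 2 of the 3 values shown sit, records. The step of an at least 1.1-fold higher number from compound 1 to compound 2 (0.07 log units; that floor lies within the scatter) cannot be sized beyond its floor, and the step that the two limits leave unreadable from compound 2 to compound 3 is unreadable.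

Compound 4 `CC(C)Cc1nn(-c2nccs2)cc1C(=O)NCc1ccc(N)cc1` differs from compound 3 by amino in place of methoxy on an aromatic carbon. The two measured steps bear only loosely on this change: an at least 1.1-fold higher number from compound 1 to compound 2 (0.07 log units; that floor lies within the scatter) shows that exchanging the aromatic substituent left the number at the limit, and a step that the two limits leave unreadable from compound 2 to compound 3 shows the same for the change on the oxygen. Among the measured compounds shown here, no measured step therefore points beyond the scatter in either direction in this assay. Compound 4 is expected to sit again near the limit, with an estimated step of a number no higher from compound 3 to compound 4 (the limit leaves the size open). The estimate for compound 4 is 100000 nM, with a range from 50000 nM to 100000 nM.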

Compound 4, half-maximal cytotoxic concentration: > 100000 nM
Compound 4 was reported as a limit (the forecaster's own chance of this, stated with the estimate: 75%); the middle value sits exactly at the limit.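

In this assay compound 4 gives > 100000 nM, which is a limit of the assay and not a number. The steps among compound 2, compound 3 and compound 4 therefore cannot be read, and the only one with a floor is an at least 1.1-fold higher number from compound 1 to compound 4 (0.07 log units; that floor lies within the scatter). What is new is that this position on the aromatic ring has now carried hydroxy, methoxy and amino, the last adding a hydrogen-bond donor in place of methoxy, and all three compounds end at the same limit: the limit of > 100000 nM in this assay, at which 3 of the 4 values shown sit.

Going by these compounds, how far the true values of these three compounds lie past that limit remains unknown, so no order among them can be given. Also open, on these data alone, is whether a carboxylic acid at this place, or a 4-fluorobenzyl group on the amide nitrogen, would bring a value inside the range of the assay.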